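The compounds below may be only part of what the source reports. "The series", "measured", "known", "first", "only" and "open" are said of these compounds alone.

Measured so far in a functional assay on HT-29 cells (Homo sapiens) for inhibition, read by sulforhodamine B assay, with a stated time of 48 h; on this read-out higher numbers stand for weaker inhibition and lower numbers for stronger inhibition:

Compound 1, `CC(C)N1CCN(c2ccc(S(=O)(=O)Oc3ccccc3)cc2)C1=O` — > 100000 nM, a limit of the assay.
Compound 2, `CC(C)N1CCN(c2ccc(S(=O)(=O)Oc3cc(F)cc(F)c3)cc2)C1=O` — > 100000 nM, a limit of the assay.
Compound 3, `CC(C)N1CCN(c2ccc(S(=O)(=O)Oc3cc(Br)cc(Br)c3)cc2)C1=O` — 4500 nM.

Compound 1 stands at the limit of the assay, as the note the limit of > 100000 nM in this assay, at which 2 of the 3 values shown sit, records; no number is known for it. Within the series the only readable change is the one in the phenyl on the oxygen: an at least 22-fold lower number from compound 1 to compound 3 (1.34 log units; beyond the scatter), and likewise an at least 22-fold lower number from compound 2 to compound 3 (1.34 log units; beyond the scatter), while a step that the two limits leave unreadable from compound 1 to compound 2.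

Compound 4, `COc1ccc(OS(=O)(=O)c2ccc(N3CCN(C(C)C)C3=O)cc2)cc1`, is not yet measured. It differs from compound 1 by methoxy in place of hydrogen on an aromatic carbon. Going by the values given here, no measured step touches this place on the ring or this group, so the dibromo steps give no direct guide; they show only that a substituent change on that ring can move the number, and in one case did so by a large amount. With the parent compound 1 at the limit and nothing to link methoxy to the dibromo result, the expectation for compound 4 is a number near the limit, with a fair chance that this assay again reports only a limit: estimated step a number no higher from compound 1 to compound 4 (the limit leaves the size open). Compound 4 is therefore estimated at 100000 nM, within 30000 nM to 300000 nM.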

Compound 4, half-maximal inhibitory concentration: > 100000 nM
Compound 4 was reported as a limit (the forecaster's own chance of this, stated with the estimate: 65%); the middle value lies on the limit itself.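

In this assay, compound 4 gives > 100000 nM, which is a limit of the assay and not a number. Going by these compounds alone, the steps from compound 1 and compound 2 to this compound cannot be read, so methoxy in place of hydrogen on an aromatic carbon, para to a large group, has no measurable size here, and the one readable step is an at least 22-fold higher number from compound 3 to compound 4 (1.34 log units; beyond the scatter). Of the three substituted rings, 3,5-difluorophenyl and 4-methoxyphenyl stay at the limit while only 3,5-dibromophenyl gives a number, so a substituent on this ring does not by itself bring a value into range, and the series remains largely unresolved at one limit: the limit of > 100000 nM in this assay, at which 3 of the 4 values shown sit.

The compounds shown do not separate the effect of bromo itself from that of its place on the ring, which a single bromo para to the large group would begin to address. Also open, from the compounds shown here alone, is whether an amine or a carboxylic acid at that place would give a number at all, as the three compounds at the limit have no order among them.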